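Removing the Nitro Group: From Compound 2 to Compound 3

The compounds below may be only part of what the source reports. "The series", "measured", "known", "first", "only" and "open" are said of these compounds alone.

Compound 1 `CC(=O)N1N=C(c2ccc3ccccc3c2)OC1c1ccccc1` gives 2.43 ug/mL
Compound 2 `CC(=O)N1N=C(c2ccc3ccccc3c2)OC1c1ccc([N+](=O)[O-])cc1` gives 7.59 ug/mL

In a functional assay on MCF7 cells (Homo sapiens) for antiproliferative activity, read by MTT assay, with a stated time of 48 h (a higher number here means a weaker inhibitor, a lower number a stronger inhibitor), compound 2 has the higher of the two numbers, which makes it the weaker inhibitor of the pair. The next structure, compound 3 `CC(=O)N1N=C(c2ccc3ccccc3c2)OC1c1ccccn1`, has pyridin-2-yl in place of 4-nitrophenyl on a saturated ring carbon, as counted in pyridin-2-yl in place of 4-nitrophenyl on a saturated ring carbon and so carries no nitro. Among the compounds with values here, only one measured step bears on this: a 3.1-fold higher number from compound 1 to compound 2 (0.49 log units; beyond the scatter) on adding nitro in place of hydrogen on an aromatic carbon. Losing the nitro should therefore give a modest step of similar size toward a lower number in this assay, although no pyridin-2-yl compound has been measured. The expected change is a 2.2-fold lower number from compound 2 to compound 3 (0.34 log units; beyond the scatter) by this estimate. Compound 3 is expected to read 3.5 ug/mL within an estimated range from 1.4 ug/mL to 9 ug/mL in this assay.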

Compound 3, half-maximal inhibitory concentration: 6.02 ug/mL
Estimate against measurement, compound 3: 1.7-fold (0.24 log units) below, and the stated range covers the measured number.
By their numbers in this assay, from the lowest: compound 1; then compounds 3 and 2 (each within the scatter of the next).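

In this assay, swapping 4-nitrophenyl for pyridin-2-yl on the saturated ring carbon gives a 1.3-fold lower number from compound 2 to compound 3 (0.10 log units; within the scatter), so these two groups cannot be told apart here. Replacing the phenyl of compound 1 with pyridin-2-yl gives a 2.5-fold higher number from compound 1 to compound 3 (0.39 log units; beyond the scatter), so both changes to that phenyl raise the number, and a ring without a nitro group need not return to the level of compound 1. Nothing available explains this behaviour. Still open, on these data alone, is whether a methoxy group or an amine on the phenyl ring would also raise the number. As far as these compounds go, it is also open whether any group on this carbon could bring the number below that of compound 1.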